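Halogen Swap on the Inactive Dichlorophenyl Analogue

A few compounds are considered here, and "the series" means these few. Any claim that something is new, unique, unknown or untested is made for them only; others in the source may bear on it.

Four compounds share one core and differ only in the aryl group attached to a double-bonded chain carbon. In a functional assay on NCI-H1975 cells (Homo sapiens) for cytotoxicity, read by CCK-8 assay, with a stated time of 72 h (on this read-out lower numbers stand for stronger inhibition and higher numbers for weaker inhibition), compound 1 `C=CCn1c(=O)/c(=C\c2ccccc2F)[nH]c(=O)/c1=C\c1ccccc1OC` gives 25100 nM. For the measured compounds named here, compound 2 `C=CCn1c(=O)/c(=C\c2cccc(Cl)c2)[nH]c(=O)/c1=C\c1ccccc1OC` gives 5100 nM in this assay, and the step of a 4.9-fold lower number from compound 1 to compound 2 (0.69 log units; beyond the scatter) is the only single-point change with numbers on both sides. Compound 3 `C=CCn1c(=O)/c(=C\c2ccc(Cl)c(Cl)c2)[nH]c(=O)/c1=C\c1ccccc1OC` is reported as "not active" (no number reported) in this assay, so no number stands for it; it can only be placed as weaker than the two compounds that returned a value.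

Going by the values given here, compound 4 `C=CCn1c(=O)/c(=C\c2cc(Br)ccc2F)[nH]c(=O)/c1=C\c1ccccc1OC` is next to be measured. 5-bromo-2-fluorophenyl in place of 3,4-dichlorophenyl on a double-bonded chain carbon bound to an aromatic carbon The entering 5-bromo-2-fluorophenyl combines elements of the 2-fluorophenyl of compound 1 and the 3-chlorophenyl of compound 2, while the leaving 3,4-dichlorophenyl belongs to the one compound without a number. The step of a 4.9-fold lower number from compound 1 to compound 2 (0.69 log units; beyond the scatter) bears on this change only loosely, since it shows how the two halogen patterns now combined behaved separately. Given that compound 1 gives 25100 nM and compound 2 gives 5100 nM, compound 4 is expected to return a number somewhere between them, with a real chance of another inactive result. Compound 4 is estimated at 12000 nM, with a range from 3000 nM to 50000 nM.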

Compound 4, half-maximal inhibitory concentration: "not active" (no number reported)
Nothing numeric was reported for compound 4, and the estimate cannot be compared.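

Compound 3 and compound 4 are both reported as "not active" in this assay, so neither has a number and no step can be read between them. No measured evidence is available to explain this result. The compounds shown leave open whether 5-bromo-2-fluorophenyl and 3,4-dichlorophenyl differ at all in this assay.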